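This account rests on a few compounds, and the source may have more. Where it says the series, first, only, none or still open, it means among the compounds named here.

Measured so far:
compound 1, `CCN(Cc1cccc(Br)c1)c1ccc(C(=O)N2CCc3ccc(OS(N)(=O)=O)cc3C2)cc1`, 97.2%
compound 2, `CCN(Cc1ccccn1)c1ccc(C(=O)N2CCc3ccc(OS(N)(=O)=O)cc3C2)cc1`, 87.7%
compound 3, `CN(C)CCN(CCN(C)C)c1ccc(C(=O)N2CCc3ccc(OS(N)(=O)=O)cc3C2)cc1`, 15.9%

Three compounds share one core and differ only in the amino group on the aromatic carbon of the benzoyl part. In an assay on HEK293 cells for inhibition of Steryl-sulfatase (Homo sapiens), tested at 1 uM (on this read-out higher numbers stand for a stronger effect at the one concentration tested and lower numbers for a weaker effect), compound 1 gives 97.2% and compound 2 gives 87.7%, a pair that differs by a number 9.5 percentage points lower from compound 1 to compound 2 (within the scatter). Compound 3 stands lowest of the three: a number 81.3 percentage points lower from compound 1 to compound 3 (beyond the scatter) and a number 71.8 percentage points lower from compound 2 to compound 3 (beyond the scatter) both drop far beyond the scatter, so on these numbers compound 3 is the weakest of the set.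

Compound 4, `CC(C)CCN(CCC(C)C)c1ccc(C(=O)N2CCc3ccc(OS(N)(=O)=O)cc3C2)cc1`, has not yet been measured. It keeps the core of compound 3 and changes one place: diisopentylamino in place of bis(2-(dimethylamino)ethyl)amino on an aromatic carbon. Going by the values given here, the steps that bear on this change are the two leading into compound 3, since each exchanges the same bis(2-(dimethylamino)ethyl)amino group against an amino group carrying two hydrocarbon arms, and each was large. Reversing that exchange in compound 4 is therefore expected to give a large rise in this assay, though the two measured partners carried ring-bearing arms, so the rise for diisopentylamino is estimated with a wide range as a number 54.1 percentage points higher from compound 3 to compound 4 (beyond the scatter). For compound 4 the expected value is 70%, estimated between 35% and 95%.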

Compound 4, a percentage reported as inhibition, at one concentration (the size of the read-out at that concentration, not a potency): 90.8%
Compound 4: the middle estimate sits 20.8 percentage points below what was measured; measured number inside the range.
By their numbers in this assay, from the lowest: compound 3; then compounds 2, 4 and 1 (each within the scatter of the next).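

Exchanging bis(2-(dimethylamino)ethyl)amino for diisopentylamino gives a number 74.9 percentage points higher from compound 3 to compound 4 (beyond the scatter) in this assay and leaves the size of the group unchanged: both groups have 11 heavy atoms and no ring, while the nitrogen count falls from 3 to 1. This shows that the low reading of compound 3 does not follow from the number of heavy atoms at this position, and that an amino group of this size can give a high reading without a ring in its arms, since a number 3.1 percentage points higher from compound 2 to compound 4 (within the scatter) and a number 6.4 percentage points lower from compound 1 to compound 4 (within the scatter) in the same assay. No measurement here explains why this exchange has such a large effect.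

The compounds shown leave open whether one terminal dimethylamino group is enough to bring the reading down, as a mixed amine with one 2-(dimethylamino)ethyl arm and one isopentyl arm would show. They also leave open how an oxygen-containing arm, such as a 2-methoxyethyl chain, or a carboxylic acid at the end of an arm would read at this position.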